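Chloro for iodo at the limit of the assay

The source may report more compounds than this note shows. Statements on the series, on what has been measured and on what is new or still open speak of the compounds shown alone.

Measured so far in a functional assay on MCF7 cells (Breast, Homo sapiens) for inhibition; on this read-out higher numbers stand for weaker inhibition of growth and lower numbers for stronger inhibition of growth:
Compound 1 `Nc1ccc(-c2nc3ccc(F)cc3s2)cc1I`: < 10 nM
Compound 2 `Cc1cc(-c2nc3c(F)cccc3s2)ccc1N`: < 10 nM
Compound 3 `Nc1ccc(-c2nc3cc(F)ccc3s2)cc1`: < 10 nM

Each of these three results is a limit of the assay and not a number. From the compounds shown here alone, compound 1 gives < 10 nM, which is a limit, so its exact place on the scale is unknown. The whole picture so far is the limit of < 10 nM in this assay, at which 3 of the 3 values shown sit. No order among the three compounds can be read from these results.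

Compound 4 `Nc1ccc(-c2nc3ccc(F)cc3s2)cc1Cl` shares the core of compound 1 and differs in one group: chloro in place of iodo on an aromatic carbon, ortho to an amino group (chloro in place of iodo on an aromatic carbon).

Going by the values given here, no pair of measured compounds shows what this swap does, so any expectation here is tentative. In this assay, no step beyond the usual scatter is expected, and the result may again be only a limit. The expected step, in estimate, is a step that the limit leaves unreadable from compound 1 to compound 4. Compound 4 is estimated at 5 nM, with an expected range from 1 nM to 20 nM.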

Compound 4, concentration for 50% growth inhibition: < 10 nM
Compound 4: no number, only a limit (the forecaster's own chance of this, stated with the estimate: 70%); the middle value does not contradict the limit.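

Going by these compounds alone, compound 1 and compound 4 each give only a limit, and no step from iodo to chloro can be read between them. The same holds for the whole set: the limit of < 10 nM in this assay, at which 4 of the 4 values shown sit.

The compounds shown leave open how they rank against one another, and whether chloro and iodo differ at all on this read-out.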